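The source may report more compounds than this note shows. Statements on the series, on what has been measured and on what is new or still open speak of the compounds shown alone.

Compounds measured in a physicochemical assay for solubility, at pH 7.4; a lower number here means a less soluble compound, a higher number a more soluble compound:
compound 1 `CCOCc1nc(Nc2ccc(C(F)(F)F)cc2)c2ccc(-c3ncccc3C(F)(F)F)cc2n1`: 0.6 ug/mL
compound 2 `CC(C)OCc1nc(Nc2ccc(C(F)(F)F)cc2)c2ccc(-c3ncccc3C(F)(F)F)cc2n1`: 0.04 ug/mL
compound 3 `O=P(O)(O)OCc1nc(Nc2ccc(C(F)(F)F)cc2)c2ccc(-c3ncccc3C(F)(F)F)cc2n1`: a limit, > 138 ug/mL; see the limit of > 138 ug/mL in this assay, at which 1 of the 3 values shown sits.

Compound 2 gives the lowest of the two numbers; the step of a 15-fold lower number from compound 1 to compound 2 (1.18 log units; beyond the scatter) separates it from compound 1. Compound 4 `FC(F)(F)c1ccc(Nc2nc(CN3CCCC3)nc3cc(-c4ncccc4C(F)(F)F)ccc23)cc1` is not yet measured. The change is pyrrolidin-1-yl in place of isopropoxy on a saturated chain carbon bound to an aromatic carbon. Within the data shown here, no measured step replaces isopropoxy with a nitrogen ring, so both steps from compound 2 are only rough guides: a 15-fold lower number from compound 1 to compound 2 (1.18 log units; beyond the scatter) and an at least 3400-fold higher number from compound 2 to compound 3 (3.53 log units; beyond the scatter), the latter ending at a limit. A higher number than compound 2 is expected, with the step of a 130-fold higher number from compound 2 to compound 4 (2.10 log units; beyond the scatter) estimated as large but far short of the limit seen for compound 3. Compound 4 is estimated at 5 ug/mL, range 0.5 ug/mL to 50 ug/mL.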

Compound 4, solubility: 25 ug/mL
Beside the measured number, compound 4's estimate is 5.0-fold (0.70 log units) below it, and the stated range covers the measured number.
By their numbers in this assay, from the lowest: compound 2; then compound 1; then compound 4. At a limit, above all of these: compound 3.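

In this assay, pyrrolidin-1-yl on the saturated chain carbon bound to an aromatic carbon gives a number well clear of both ether compounds: a 630-fold higher number from compound 2 to compound 4 (2.80 log units; beyond the scatter) and a 42-fold higher number from compound 1 to compound 4 (1.62 log units; beyond the scatter). Until now, only the phosphorus-bearing group of compound 3 had stood far above them; a group without phosphorus now does so too. Compound 3 remains a limit of the assay, > 138 ug/mL, so an at least 5.5-fold lower number from compound 3 to compound 4 (0.74 log units; beyond the scatter) is only a bound.

Going by these compounds, whether the step follows the ring nitrogen or the ring itself stays open. An open-chain dimethylamino group or a cyclopentyl ring at this place would separate the two.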